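Demethylation of the methoxy in a urea-pyrazole series

A few compounds are considered here, and "the series" means these few. Any claim that something is new, unique, unknown or untested is made for them only; others in the source may bear on it.

Measured compounds:
Compound 1, `O=C(Nc1cccc(-n2cc(-c3ccncc3)c(-c3ccc(Cl)c(O)c3)n2)c1)Nc1ccc(Cl)c(Cl)c1`: > 32500 nM
Compound 2, `COc1cc(-c2nn(-c3cccc(NC(=O)Nc4ccc(Cl)c(C(F)(F)F)c4)c3)cc2-c2ccncc2)ccc1Cl`: > 32500 nM

The study tests growth inhibition in a functional assay on DU-145 cells (Homo sapiens) for inhibition, read by sulforhodamine B assay, with a stated time of 48 h; on this read-out lower numbers stand for stronger inhibition of growth and higher numbers for weaker inhibition of growth. Compound 1, `O=C(Nc1cccc(-n2cc(-c3ccncc3)c(-c3ccc(Cl)c(O)c3)n2)c1)Nc1ccc(Cl)c(Cl)c1`, gives > 32500 nM in this assay, and this figure is a limit of the assay rather than a number. Compound 2, `COc1cc(-c2nn(-c3cccc(NC(=O)Nc4ccc(Cl)c(C(F)(F)F)c4)c3)cc2-c2ccncc2)ccc1Cl`, likewise gives > 32500 nM in this assay, again a limit and not a number. Compound 2 therefore stands at the limit of > 32500 nM in this assay, at which 2 of the 2 values shown sit, and nothing places it above or below compound 1.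

Compound 3, `O=C(Nc1cccc(-n2cc(-c3ccncc3)c(-c3ccc(Cl)c(O)c3)n2)c1)Nc1ccc(Cl)c(C(F)(F)F)c1`, has not yet been measured in this assay. It differs from compound 2 by hydrogen in place of methyl on an oxygen on an aromatic ring, which is hydrogen in place of methyl on an oxygen on an aromatic ring, so that 4-chloro-3-methoxyphenyl becomes 4-chloro-3-hydroxyphenyl. Within the data shown here, no step between measured compounds covers this change, and both measured compounds sit at a limit, so no direction for the step can be read from the data. The step from compound 2 to compound 3 is therefore expected to be a step that the limit leaves unreadable from compound 2 to compound 3, within the scatter. Compound 3 is estimated to give 40000 nM in this assay, with a range from 10000 nM to 120000 nM.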

Compound 3, concentration for total growth inhibition: 4630 nM
For compound 3 the middle estimate is 8.6-fold (0.94 log units) above the measured one; the measured number lies below the stated range.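

In this assay, compound 3 is the first compound shown to give a number rather than a limit, and the place on the oxygen on the aromatic ring turns out to respond: hydrogen in place of methyl, methoxy to hydroxy, gives an at least 7.0-fold lower number from compound 2 to compound 3 (0.84 log units; beyond the scatter). The chloro position on the aromatic carbon of the urea's other aryl group responds as well, with trifluoromethyl in place of chloro giving an at least 7.0-fold lower number from compound 1 to compound 3 (0.84 log units; beyond the scatter). Compound 3 carries the hydroxy and the trifluoromethyl together, while compound 1 has only the hydroxy and compound 2 only the trifluoromethyl, and each of those two stays at a limit, so both steps are open-ended: the limit of > 32500 nM in this assay, at which 2 of the 3 values shown sit.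

The compounds shown leave open whether a free hydroxy is specifically required at this place or whether an amine or a carboxylic acid there would serve as well. As far as these compounds go, the true size of either step also remains unknown, and so does whether the two changes simply add up or depend on each other.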